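Replacing the 2-phenylethenyl group of compound 2

The source may hold more compounds than are shown below. What is called first, only, known or untested is meant among the compounds shown, and "the series" means these compounds.

Among the measured compounds shown here, in an ADME assay on L6 cells (Rattus norvegicus) for cytotoxicity, with a stated time of 72 h (a lower number here means a stronger inhibitor, a higher number a weaker inhibitor), compound 2 `O=C(/C=C/c1ccccc1)OC1CC2(N3CCCC3)CC(c3ccccc3)C1C(c1ccccc1)C2` gives 3500 nM and holds the lower of the two numbers so far. Compound 1 `CCN(CC)CC(=O)OC1CC2(N(C)C)CC(c3ccccc3)C1C(c1ccccc1)C2` gives 30100 nM and stands higher, a gap beyond the scatter.

Next in line is compound 3 `CCN(CC)CC(=O)OC1CC2(N3CCCC3)CC(c3ccccc3)C1C(c1ccccc1)C2`, which keeps everything in compound 2 except one group: (diethylamino)methyl in place of 2-phenylethenyl on a carbonyl carbon. The leaving group takes its six-membered aromatic ring with it, and the entering group has no ring.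

For the measured compounds named here, no measured pair isolates this change. The nearest guide is compound 1, which carries the same (diethylamino)methyl and gives 30100 nM but also differs from compound 3 elsewhere, so the expectation rests on thin evidence. A move towards a higher number, meaning a weaker inhibitor, is expected, of a size beyond the scatter. The estimated step is a 5.7-fold higher number from compound 2 to compound 3 (0.76 log units; beyond the scatter) in this assay and would place the new value close to that of the other (diethylamino)methyl compound. For compound 3 the estimated value is 20000 nM with an expected range of 7000 nM to 55000 nM around it.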

Compound 3, half-maximal inhibitory concentration: 49000 nM
Compound 3: middle estimate off by 2.5-fold (0.39 log units), on the low side; measured number inside the range.
By their numbers in this assay, from the lowest: compound 2; then compounds 1 and 3 (each within the scatter of the next).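

In this assay the change from 2-phenylethenyl to (diethylamino)methyl on a carbonyl carbon gives a 14-fold higher number from compound 2 to compound 3 (1.15 log units; beyond the scatter) and is the first direct reading of this position: among these compounds, the group carrying the six-membered aromatic ring goes with the lower number. Pyrrolidin-1-yl in place of dimethylamino on a saturated ring carbon gives a 1.6-fold higher number from compound 1 to compound 3 (0.21 log units; within the scatter) with (diethylamino)methyl held constant, so this assay does not separate those two amines in that setting, and the large step among the three compounds lies at the carbonyl carbon. No measurement at hand gives a cause for either step.

From the compounds shown here alone, each change rests on one pair, so it remains open whether the step at the carbonyl carbon would be of similar size with dimethylamino on the saturated ring carbon, or whether the amine on that ring carbon matters when 2-phenylethenyl is present. The compounds shown also leave open which part of 2-phenylethenyl goes with the lower number, a question that a 2-phenylethyl chain or a phenyl group directly on the carbonyl carbon would address.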